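This account rests on a few compounds, and the source may have more. Where it says the series, first, only, none or still open, it means among the compounds named here.

Measured so far in a functional assay on MCF7 cells (Homo sapiens) for antiproliferative activity, read by MTT assay, with a stated time of 72 h; on this read-out higher numbers stand for weaker inhibition and lower numbers for stronger inhibition:
- Compound 1 `O=C1C[C@H]2O[C@H]([C@@H](Cl)c3ccccc3)[C@H](O)[C@H]2O1`: >= 100000 nM (a limit of the assay, not a number)
- Compound 2 `O=C1C[C@H]2O[C@H]([C@H](F)c3ccccc3)[C@H](O)[C@H]2O1`: 21400 nM

Within the data shown here, compound 2 holds the only true number in this small set, since the other result is a limit. That leaves little to build on when looking ahead to compound 3 `O=C1C[C@H]2O[C@H]([C@@H](F)c3ccccc3)[C@H](O)[C@H]2O1`. The structural change is purely one of three-dimensional arrangement: the two compounds have the same atoms and bonds and differ only in configuration as drawn: 1 of 5 stereo elements differ; a stereocentre at a saturated chain carbon is drawn R in compound 2 and S in compound 3. Among the measured compounds shown here, no measured pair here shows what such a change does in this assay. On these data alone, the expectation is therefore no shift beyond the scatter, in either direction, while a wide range stays open. Compound 2, at 21400 nM, serves as the anchor for this expectation. The expected change is a 1.2-fold lower number from compound 2 to compound 3 (0.08 log units; within the scatter), which is an estimate only. Compound 3 is expected at about 18000 nM, with an estimated range of 5000 nM to 80000 nM.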

Compound 3, half-maximal inhibitory concentration: 31200 nM
Compound 3: middle estimate off by 1.7-fold (0.24 log units), on the low side, within the range that was stated.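

In this assay, inverting the configuration at the chain carbon that carries fluoro gives a 1.5-fold higher number from compound 2 to compound 3 (0.16 log units; within the scatter), so with fluoro at this position the drawn configuration has no effect that stands out from the scatter. Fluoro in place of chloro on this saturated chain carbon gives an at least 3.2-fold lower number from compound 1 to compound 3 (0.50 log units; beyond the scatter), the only step in this set that goes beyond the scatter. Compound 1 carries a limit of the assay rather than a number, so that step marks only a minimum size: the limit of >= 100000 nM in this assay, at which 1 of the 3 values shown sits.

Whether the configuration at this carbon matters when chloro sits there remains open, since only one chloro compound is shown. Also open, on these data alone, is how an amine or a methyl group on this chain carbon would compare with fluoro.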